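The compounds below may be only part of what the source reports. "The series", "measured", "known", "first", "only" and "open" are said of these compounds alone.

The measured compounds are:
compound 1, `COC(=O)C1=C(C)N=C(C)/C(=C(/O)OC)C1c1c(F)cccc1Cl`, giving 7.59 nM;
compound 2, `COC(=O)C1=C(C)N=C(C)/C(=C(\O)OC)C1c1ccccc1C#N`, giving 15.9 nM;
compound 3, `COC(=O)C1=C(C)N=C(C)/C(=C(\O)OC)C1c1ccccc1C(F)(F)F`, giving 1.51 nM.

All three were tested in a functional assay (muscle tissue) with Cavia porcellus as the target; a higher number here means that more compound is needed for the effect, a lower number that less compound is needed. Compound 2 stands at the top of the three numbers; compound 1 is the nearest to it, and compound 3 lies furthest away. Within the data shown here, the only measured step that starts from compound 2 is an 11-fold lower number from compound 2 to compound 3 (1.02 log units; beyond the scatter), a single swap of one group on the aromatic ring. Among the measured compounds shown here, no measured pair tells what happens when the substituent moves to a different position on the ring, or when a small halogen replaces the nitrile.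

Compound 4, `COC(=O)C1=C(C)N=C(C)/C(=C(\O)OC)C1c1cccc(F)c1`, differs from compound 2 as follows: 3-fluorophenyl in place of 2-cyanophenyl on a saturated ring carbon. Both the identity of the group and its position on the ring change at once, so the step from compound 2 to compound 3 bears on it only loosely: it shows that exchanging the group on this ring can move the number by a large amount, but not in which direction a fluorine at a new position would. Compound 4 is expected to give 6 nM, with a range from 1.5 nM to 25 nM. That estimate corresponds to a 2.7-fold lower number from compound 2 to compound 4 (0.42 log units; beyond the scatter), a modest expected change that is held close to compound 2 by the absence of any directly comparable measured step.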

Compound 4, half-maximal effective concentration: 20.9 nM
The estimate for compound 4 lay 3.5-fold (0.54 log units) below the measured number; the range from low to high includes it.
By their numbers in this assay, from the lowest: compound 3; then compound 1; then compounds 2 and 4 (each within the scatter of the next).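

The change from 2-cyanophenyl to 3-fluorophenyl on the saturated ring carbon appears in this assay as a 1.3-fold higher number from compound 2 to compound 4 (0.12 log units; within the scatter) and leaves the two compounds indistinguishable, even though both the group and its position on the aromatic ring differ. A change to the aromatic group at this place therefore need not move the number much, in contrast to trifluoromethyl in place of cyano, which gives an 11-fold lower number from compound 2 to compound 3 (1.02 log units; beyond the scatter) and lies beyond the scatter. No information is available here to explain why one change matters and the other does not.

The compounds shown contain no pair in which a fluorine replaces the nitrile at the same ring position, or in which one group simply moves around the ring, so the effects of group and position remain tangled together, and the close match between compound 2 and compound 4 could reflect either little effect from both or two effects that cancel. On these data alone, how an amine or a carboxylic acid on this aromatic ring would behave also remains open.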